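An Azide Swapped for an Aminopropylamine Tail

The compounds below may be only part of what the source reports. "The series", "measured", "known", "first", "only" and "open" are said of these compounds alone.

Compound 1 `CCCCCCCCCO[C@@H]1[C@@H](N)[C@@H](OCC(O)CNCCCO)O[C@H](CN)[C@H]1OCCCCCCCCC` gives 89.9% in a toxicity assay on the whole organism (J774 cells) for cytotoxicity, with Mus musculus as the target, read by MTT assay, with a stated time of 24 h, tested at 10 uM; a higher number here means a weaker effect of the compound at the concentration tested, a lower number a stronger effect.
Compound 2 `CCCCCCCCCO[C@@H]1[C@@H](N)[C@@H](O[C@H]2[C@H](O)[C@@H](O)[C@H](N)C[C@@H]2N)O[C@H](CN)[C@H]1OCCCCCCCCC` gives 82.7% in this assay.
Compound 3 `CCCCCCCCCO[C@@H]1[C@@H](N)[C@@H](OC[C@H](O)CN=[N+]=[N-])O[C@H](CN)[C@H]1OCCCCCCCCC` gives 62.2% in this assay.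

Compound 3 stands lowest of the three, meaning it acts most strongly on the cells at the tested concentration. Its nearest neighbour is compound 2, a number 20.5 percentage points lower from compound 2 to compound 3 (beyond the scatter), and the furthest is compound 1, a number 27.7 percentage points lower from compound 1 to compound 3 (beyond the scatter).

Compound 4 `CCCCCCCCCO[C@@H]1[C@@H](N)[C@@H](OCC(O)CNCCCN)O[C@H](CN)[C@H]1OCCCCCCCCC` is reached from compound 3 by one change: 2-((3-aminopropyl)amino)-1-hydroxyethyl in place of 2-azido-1-hydroxyethyl on a saturated chain carbon bound to an oxygen on a saturated carbon. The group that enters closely resembles the group carried by compound 1, so the step from compound 1 to compound 3 is the one that bears most directly here: a number 27.7 percentage points lower from compound 1 to compound 3 (beyond the scatter). Read in reverse, replacing the azide with an amine-bearing chain raised the number by a modest amount. The step of a number 20.5 percentage points lower from compound 2 to compound 3 (beyond the scatter) points the same way, with the azide compound again lowest. The change to compound 4 is therefore expected to raise the number in this assay by a modest amount, a number 22.8 percentage points higher from compound 3 to compound 4 (beyond the scatter), with room for some deviation since the entering chain ends in an amino group rather than a hydroxyl. For compound 4 the expected value in this assay is 85%, estimated between 66% and 100%.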

Compound 4, a percentage reported as activity, at one concentration (the size of the read-out at that concentration, not a potency): 101%
The estimate for compound 4 lay 16 percentage points below the measured number, outside the stated range (above it).
By their numbers in this assay, from the lowest: compound 3; then compounds 2 and 1 (each within the scatter of the next); then compound 4.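

Replacing the azide chain with the 3-((3-aminopropyl)amino)-2-hydroxypropyl group gives the largest step seen so far in this assay, a number 38.8 percentage points higher from compound 3 to compound 4 (beyond the scatter), so this position can carry the compound from the strongest effect among the four to the weakest. The far end of the chain also counts: amino in place of hydroxy gives a number 11.1 percentage points higher from compound 1 to compound 4 (beyond the scatter), which shows that compound 1 and compound 4 are separated by that single end group, while the step to the same chain from the 4,6-diamino-2,3-dihydroxycyclohexyl group is a number 18.3 percentage points higher from compound 2 to compound 4 (beyond the scatter). Nothing among the data explains why these steps have the sizes they do.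

As far as these compounds go, whether the end amine needs this exact spacing stays open, since a longer chain between the two nitrogens, or a dimethylamino or guanidine group at the chain end, could move the number either way. The change also removes one defined stereocentre along with the azide, so the effect of that centre cannot be separated from the effect of the new chain.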